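This account rests on a few compounds, and the source may have more. Where it says the series, first, only, none or still open, it means among the compounds named here.

Compound 1 `COc1cc2c(cc1OC)C(c1cccc([N+](=O)[O-])c1)=NNC(=O)C2`: > 120 umol/kg (a limit)
Compound 2 `COc1cc2c(cc1OC)C(c1ccccc1)=NN(C)C(=S)C2`: 30.6 umol/kg

Among the compounds with values here, in a functional assay on the whole organism with Mus musculus as the target (on this read-out higher numbers stand for an effect only at larger amounts of compound and lower numbers for an effect already at smaller amounts), compound 2 gives 30.6 umol/kg, the only actual number so far. Compound 1 is recorded only as a limit, > 120 umol/kg.

Compound 3 `COc1cc2c(cc1OC)C(c1ccc([N+](=O)[O-])cc1)=NN(C)C(=S)C2` differs from compound 2 by nitro in place of hydrogen on an aromatic carbon, para to a large group. Within the data shown here, no measured pair shows this change, so the size of the step remains open. A small shift toward larger doses in this assay is expected, a 1.6-fold higher number from compound 2 to compound 3 (0.21 log units; within the scatter), not clearly beyond the scatter. Compound 3 is estimated at 50 umol/kg, with an expected range of 20 umol/kg to 120 umol/kg.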

Compound 3, dose for half-maximal effect: 103 umol/kg
For compound 3 the middle estimate is 2.1-fold (0.31 log units) below the measured one; the measured number falls inside the stated range.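

In this assay nitro in place of hydrogen on an aromatic carbon, para to a large group, gives a 3.4-fold higher number from compound 2 to compound 3 (0.53 log units; beyond the scatter) and so moves the series toward larger doses. Within the data shown here, this is the first measured sign that this position responds to substitution, though it rests on a single pair. Any further upward step from compound 3 would soon meet a limit rather than a number: the limit of > 120 umol/kg in this assay, at which 1 of the 3 values shown sits.

As far as these compounds go, whether an amine, a carboxylic acid or a methoxy group on the same carbon moves the number in the same direction remains open.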